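The source may hold more compounds than are shown below. What is called first, only, known or untested is meant among the compounds shown, and "the series" means these compounds.

Within the data shown here, in a functional assay on LOX IMVI cells (Homo sapiens) for inhibition (on this read-out lower numbers stand for stronger inhibition of growth and higher numbers for weaker inhibition of growth), compound 1 `NC(=O)c1cc(Cl)ccc1NC(=O)COc1ccccc1` gives 8330 nM and compound 2 `NC(=O)c1cc(I)ccc1NC(=O)COc1ccccc1` gives 822 nM as the lower of the two numbers measured so far. Compound 3 `COc1ccc(NC(=O)COc2ccccc2)c(C(N)=O)c1` follows from compound 2 with methoxy in place of iodo on an aromatic carbon at the same place, meta to a carbamoyl group and para to a large group. Among the measured compounds shown here, one measured step bears on this place: a 10-fold lower number from compound 1 to compound 2 (1.01 log units; beyond the scatter) with iodo in place of chloro, a large change beyond the scatter. For the measured compounds named here, no methoxy compound has been measured, so this is only a rough guide. Read in reverse, that step suggests that losing iodo will move the number upward by a large amount, perhaps somewhat less than that step. The expected change is a 7.3-fold higher number from compound 2 to compound 3 (0.86 log units; beyond the scatter) and would lie beyond the scatter. Compound 3 is estimated at 6000 nM with an expected range of 2000 nM to 18000 nM in this series.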

Compound 3, concentration for 50% growth inhibition: 869 nM
Compound 3: middle estimate off by 6.9-fold (0.84 log units), on the high side; the whole stated range lies above it.
By their numbers in this assay, from the lowest: compounds 2 and 3 (each within the scatter of the next); then compound 1.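

In this assay, methoxy in place of iodo gives a 1.1-fold higher number from compound 2 to compound 3 (0.02 log units; within the scatter), so the low number at this aromatic carbon is not tied to iodo alone. Methoxy in place of chloro gives a 9.6-fold lower number from compound 1 to compound 3 (0.98 log units; beyond the scatter), which sets beside a 10-fold lower number from compound 1 to compound 2 (1.01 log units; beyond the scatter) a second replacement of chloro that lies beyond the scatter. This place therefore accepts two groups that differ in atoms, heavy-atom count and hydrogen-bond acceptors without any separation beyond the scatter between compound 2 and compound 3, and among the three compounds chloro alone stands apart.

No supporting measurement accounts for this match or for the position of chloro. As far as these compounds go, it remains open whether an amine, a carboxylic acid or a longer alkoxy chain at this place would read with compound 2 and compound 3 or with compound 1.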